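Swapping the dichlorophenyl for a nitrophenyl on compound 3

The source may hold more compounds than are shown below. What is called first, only, known or untested is meant among the compounds shown, and "the series" means these compounds.

Compound 1 `O=c1ccoc2cc(OCc3cn(Cc4ccccc4)nn3)ccc12` gives > 100000 nM in a functional assay on QGY7701 cells (Homo sapiens) for cytotoxicity, read by MTT assay, with a stated time of 48 h (on this read-out higher numbers stand for weaker inhibition and lower numbers for stronger inhibition), which is a limit and not a number.
Compound 2 `Cc1ccc(Cn2cc(COc3ccc4c(=O)ccoc4c3)nn2)cc1` gives 68500 nM in this assay.
Compound 3 `O=c1ccoc2cc(OCc3cn(Cc4ccc(Cl)cc4Cl)nn3)ccc12` gives 13300 nM in this assay.

Compound 3 holds the lowest of the two numbers; compound 2 is nearest, as a 5.2-fold lower number from compound 2 to compound 3 (0.71 log units; beyond the scatter) shows. Compound 1 stands at a limit (the limit of > 100000 nM in this assay, at which 1 of the 3 values shown sits). Compound 4 `O=c1ccoc2cc(OCc3cn(Cc4cccc([N+](=O)[O-])c4)nn3)ccc12` differs from compound 3 by 3-nitrophenyl in place of 2,4-dichlorophenyl on a saturated chain carbon bound to an aromatic nitrogen. Among the measured compounds shown here, the steps that bear on this are an at least 7.5-fold lower number from compound 1 to compound 3 (0.87 log units; beyond the scatter) and a 5.2-fold lower number from compound 2 to compound 3 (0.71 log units; beyond the scatter), both of which replaced a plain or methyl-bearing phenyl with the dichlorophenyl and lowered the number. For the measured compounds named here, no measured step introduces a nitrophenyl, so its effect is unknown; the expected step is a 2.6-fold higher number from compound 3 to compound 4 (0.42 log units; beyond the scatter), a rise toward the other two compounds. Compound 4 is therefore estimated at 35000 nM, between 8000 nM and 150000 nM.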

Compound 4, half-maximal inhibitory concentration: 14100 nM
Compound 4: the middle estimate sits 2.5-fold (0.39 log units) above what was measured; the range from low to high includes it.
By their numbers in this assay, from the lowest: compounds 3 and 4 (each within the scatter of the next); then compound 2. At a limit, above all of these: compound 1.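

At the saturated chain carbon bound to an aromatic nitrogen, two quite different substituted phenyl groups now read alike in this assay, so chlorine is not needed to reach this level: a 1.1-fold higher number from compound 3 to compound 4 (0.03 log units; within the scatter). The 3-nitrophenyl also improves on the other groups, with a 4.9-fold lower number from compound 2 to compound 4 (0.69 log units; beyond the scatter) and an at least 7.0-fold lower number from compound 1 to compound 4 (0.85 log units; beyond the scatter). The second of these steps rests on a limit, which belongs to compound 1: the limit of > 100000 nM in this assay, at which 1 of the 4 values shown sits.

As far as these compounds go, whether a single chlorine would be enough remains open. So does whether a 4-nitrophenyl or an aminophenyl would hold this level.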